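The source may hold more compounds than are shown below. What is called first, only, known or untested is meant among the compounds shown, and "the series" means these compounds.

Within the data shown here, compound 2 `CCCc1nc(-c2ccccc2)c(CNCCN2CCN(c3ccc(F)cc3)CC2)o1` is one of two compounds measured in an assay on HEK293 cells for inhibition of Voltage-dependent T-type calcium channel subunit alpha-1G (Homo sapiens), read by fluorescence, tested at 10 uM; on this read-out higher numbers stand for more inhibition at the one concentration tested (going by the name of the read-out) and lower numbers for less inhibition. In this assay compound 2 gives 54.1%, the lowest of the two numbers. Its nearest neighbour is compound 1 `CCCc1nc(-c2ccccc2)c(CNCCN2CCN(c3ccccc3Cl)CC2)o1`, which in this assay gives 60.1%; the step of a number 6 percentage points lower from compound 1 to compound 2 (within the scatter) lies within the scatter, so the two compounds cannot be told apart on these numbers.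

Compound 3 `CCCc1nc(-c2ccccc2)c(CNCCN2CCN(c3ccccc3C(F)(F)F)CC2)o1` is not yet measured. It differs from compound 2 in one place: 2-(trifluoromethyl)phenyl in place of 4-fluorophenyl on an amine nitrogen in a ring.

Among the measured compounds shown here, only one measured step bears on this change. Going from compound 1 to compound 2, a 2-chlorophenyl on the same ring nitrogen was exchanged for a 4-fluorophenyl, and that exchange gave a number 6 percentage points lower from compound 1 to compound 2 (within the scatter), a change too small to matter. Compound 3 again carries a substituted phenyl on that nitrogen, this time a 2-(trifluoromethyl)phenyl, and on the evidence of that single step no movement beyond the scatter is expected in this assay. The estimated step of a number 3.9 percentage points higher from compound 2 to compound 3 (within the scatter) is therefore expected to be small. For compound 3 the estimate in this assay is 58%, with a range from 40% to 76%.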

Compound 3, a percentage reported as inhibition, at one concentration (the size of the read-out at that concentration, not a potency): 54.6%
For compound 3 the middle estimate is 3.4 percentage points above the measured one; low and high end bracket the measured number.
By their numbers in this assay, from the lowest: compounds 2, 3 and 1 (each within the scatter of the next).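

In this assay, the step of a number 0.5 percentage points higher from compound 2 to compound 3 (within the scatter) shows that 2-(trifluoromethyl)phenyl, with 10 heavy atoms against the 7 of 4-fluorophenyl, can stand on this amine nitrogen in a ring without a difference that can be told from the scatter. The second new step, a number 5.5 percentage points lower from compound 1 to compound 3 (within the scatter), adds a direct comparison of trifluoromethyl in place of chloro on an aromatic carbon, and this difference also cannot be told from the scatter, so the three groups tried on this nitrogen cannot be separated at the one concentration tested. Nothing in the available data explains why these three compounds read alike.

The compounds shown leave open whether a group without an aromatic ring on this nitrogen, such as cyclohexyl, or a plain methyl, would give a number beyond the scatter. They also leave open whether a change elsewhere on the shared core, such as a carboxylic acid or a longer chain, would matter more than the changes on this nitrogen.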